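The source may report more compounds than this note shows. Statements on the series, on what has been measured and on what is new or still open speak of the compounds shown alone.

In a functional assay on HUVEC cells (Homo sapiens) for inhibition, with stated times of 2 h and 72 h (a lower number here means a stronger inhibitor, a higher number a weaker inhibitor), compound 1 (`COc1cc2nccc(Oc3ccc4c(NC(=O)c5cccc(C(F)(F)F)c5)nn(C)c4c3)c2cc1OC`) gives > 1000 nM, which is a limit and not a number. Compound 2 (`COc1cc2nccc(Oc3ccc4c(NC(=O)Nc5ccc(C(F)(F)F)cc5Cl)nn(C)c4c3)c2cc1OC`) gives > 1000 nM, which is also a limit, and it stands with compound 1 at the limit of > 1000 nM in this assay, at which 2 of the 2 values shown sit. Among the measured compounds shown here, the one measured step, a step that the two limits leave unreadable from compound 1 to compound 2, offers no size to carry forward. Compound 3 (`COc1cc2nccc(Oc3ccc4c(NC(=O)C5CC5)nn(C)c4c3)c2cc1OC`) differs from compound 2 by cyclopropyl in place of (2-chloro-4-(trifluoromethyl)phenyl)amino on a carbonyl carbon, with cyclopropyl in place of (2-chloro-4-(trifluoromethyl)phenyl)amino on a carbonyl carbon. The measurements show no direction, so the expected step, a step that the limit leaves unreadable from compound 2 to compound 3, is only a rough estimate. Compound 3 is expected near 2000 nM, within an estimated range of 400 nM to 10000 nM.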

Compound 3, half-maximal inhibitory concentration: > 1000 nM
Compound 3: only a limit was reported (the forecaster's own chance of this, stated with the estimate: 65%); the middle value lies beyond the limit too.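

Among the compounds shown here, no step among compound 1, compound 2 and compound 3 can be read in this assay, since each gives only a limit: the limit of > 1000 nM in this assay, at which 3 of the 3 values shown sit. As far as these compounds go, how strongly any of the three inhibits, and how the groups on the carbonyl carbon compare, stays open.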